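Methoxy for methyl on the fused ring: compound 4

A few compounds are considered here, and "the series" means these few. Any claim that something is new, unique, unknown or untested is made for them only; others in the source may bear on it.

Measured so far in an assay on HEK293 cells for displacement of a labelled ligand from 5-hydroxytryptamine receptor 6 (Homo sapiens); on this read-out lower numbers stand for stronger inhibition and higher numbers for weaker inhibition:
compound 1 `O=S(=O)(c1ccccc1)N1CCOc2c(N3CCNCC3)cccc21` gives 12.6 nM
compound 2 `Cc1cc(N2CCNCC2)c2c(c1)N(S(=O)(=O)c1ccccc1)CCO2` gives 2.51 nM
compound 3 `Cc1cc(N2CCNCC2)c2c(c1)N(S(=O)(=O)c1ccccc1F)CCO2` gives 0.398 nM

Compound 2 stands second highest of the three numbers in this assay: compound 1 sits above it, a 5.0-fold lower number from compound 1 to compound 2 (0.70 log units; beyond the scatter), and compound 3 sits below it, a 6.3-fold lower number from compound 2 to compound 3 (0.80 log units; beyond the scatter).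

Compound 4 `COc1cc(N2CCNCC2)c2c(c1)N(S(=O)(=O)c1ccccc1)CCO2` is not yet measured. It differs from compound 2 in one place: methoxy in place of methyl on an aromatic carbon.

Neither measured step repeats this change. The step from compound 1 to compound 2 shows that putting a methyl at this place lowers the number modestly, a 5.0-fold lower number from compound 1 to compound 2 (0.70 log units; beyond the scatter). The step from compound 2 to compound 3 concerns the other aromatic ring, a 6.3-fold lower number from compound 2 to compound 3 (0.80 log units; beyond the scatter), and says nothing about the fused ring. How a methoxy at the same place compares with a methyl is therefore open on these data; the place is tolerant of a small group, but whether the added oxygen helps, hurts or is neutral cannot be read from compounds 1 to 3.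

The expectation for compound 4 is therefore a number close to that of compound 2, with a step of a 1.2-fold higher number from compound 2 to compound 4 (0.08 log units; within the scatter) in this assay, which lies within the scatter. The estimate for compound 4 is 3 nM, with a range from 0.8 nM to 12 nM.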

Compound 4, inhibition constant: 0.398 nM
The estimate for compound 4 lay 7.5-fold (0.88 log units) above the measured number, outside the stated range (below it).
By their numbers in this assay, from the lowest: compounds 3 and 4 (each within the scatter of the next); then compound 2; then compound 1.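

In this assay, the aromatic carbon that is meta to a piperazin-1-yl group does more than tolerate a small group: it separates methoxy from methyl, with the change giving a step beyond the scatter (a 6.3-fold lower number from compound 2 to compound 4 (0.80 log units; beyond the scatter)). Measured from hydrogen at the same carbon, the methoxy step is large (a 32-fold lower number from compound 1 to compound 4 (1.50 log units; beyond the scatter)), so hydrogen to methyl and methyl to methoxy both lower the number in this short set. Nothing measured here accounts for the step from methyl to methoxy, so the entering oxygen and its single hydrogen-bond acceptor are counted features of the change and not an established cause.

As far as these compounds go, whether the oxygen itself or the longer group matters remains open, and a hydroxy group, an ethoxy group or a dimethylamino group at this carbon would help separate these readings. Among the compounds shown here, also open is whether the methoxy and the fluoro on the other aromatic ring would combine in the same molecule, since each has so far been seen only on its own.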